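A few compounds are considered here, and "the series" means these few. Any claim that something is new, unique, unknown or untested is made for them only; others in the source may bear on it.

Three compounds have been measured in a functional assay on CHO cells for agonist activity at adenosine receptor A1 (Homo sapiens), read by fluorescence and ERK phosphorylation, with stated times of 30 min and 1.5 h, tested at 10 uM; on this read-out lower numbers stand for a weaker effect and higher numbers for a stronger effect at the one concentration tested:

compound 1, `Nc1scc(-c2cccc(F)c2)c1C(=O)c1ccccc1`, gives 52%
compound 2, `Nc1scc(-c2cccc(Cl)c2)c1C(=O)c1ccccc1`, gives 52%
compound 3, `Nc1scc(-c2ccc(Cl)cc2)c1C(=O)c1ccccc1`, gives 51%

Compound 3 holds the lowest of the three numbers, but only just: the step of a number 1 percentage points lower from compound 1 to compound 3 (within the scatter) and the step of a number 1 percentage points lower from compound 2 to compound 3 (within the scatter) both lie within the scatter, so compound 3 cannot be set apart from either of the others. Likewise the step of no change at the digits printed from compound 1 to compound 2 (within the scatter) shows that exchanging one halogen for another at the same place left the read-out unmoved.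

Compound 4, `Nc1scc(-c2cccc(Br)c2)c1C(=O)c1ccccc1`, differs from compound 3 by 3-bromophenyl in place of 4-chlorophenyl on an aromatic carbon. Among the measured compounds shown here, two measured steps bear on this change: the halogen swap in no change at the digits printed from compound 1 to compound 2 (within the scatter) and the move of the chlorine around the ring in a number 1 percentage points lower from compound 2 to compound 3 (within the scatter), neither of which reached beyond the scatter. Nothing measured here points to a larger effect for bromine. Compound 4 is therefore expected to give 52%, within a range from 42% to 62%, which amounts to an expected step of a number 1 percentage points higher from compound 3 to compound 4 (within the scatter), that is, no change beyond the scatter.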

Compound 4, a percentage reported as activity, at one concentration (the size of the read-out at that concentration, not a potency): 76%
The estimate for compound 4 lay 24 percentage points below the measured number, outside the stated range (above it).
By their numbers in this assay, from the lowest: compounds 3, 1 and 2 (each within the scatter of the next); then compound 4.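

In this assay, the halogen on the phenyl group at this position of the shared core proves able to move the read-out: bromo in place of chloro gives a number 24 percentage points higher from compound 2 to compound 4 (beyond the scatter) and bromo in place of fluoro gives a number 24 percentage points higher from compound 1 to compound 4 (beyond the scatter), whereas the earlier exchange of chloro for fluoro gave no such shift. The change from the 4-chlorophenyl group to the 3-bromophenyl group also lies beyond the scatter, with a number 25 percentage points higher from compound 3 to compound 4 (beyond the scatter), so compound 4 alone stands apart from the other three. Nothing available accounts for this rise with bromine.

On these data alone, it remains open whether a 4-bromophenyl group would match the 3-bromophenyl group, and whether an iodo, methoxy or trifluoromethyl group on the phenyl ring would carry the read-out further or lose the gain. A reading at one concentration also leaves open whether compound 4 would give a stronger effect than the others at other concentrations.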